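Carboxy for hydrogen on the propylamide chain of a bicyclic diacid

A few compounds are considered here, and "the series" means these few. Any claim that something is new, unique, unknown or untested is made for them only; others in the source may bear on it.

The series rests on a shared core carrying an amide and a free carboxylic acid. Compound 1 `CCCNC(=O)C1C(C(=O)O)[C@@H]2CC[C@H]1O2` gives, in an ADME assay on MCF7 cells (Homo sapiens) for cytotoxicity, read by MTT assay, with a stated time of 72 h (on this read-out lower numbers stand for stronger inhibition of growth and higher numbers for weaker inhibition of growth), a value of 10000 nM. Compound 2 `C/C(=N/Nc1ccccc1)c1ccccc1NC(=O)C1C(C(=O)O)[C@@H]2CC[C@H]1O2`, which carries a much larger amide substituent, gives in this assay a value of 10000 nM. Compound 1 thus stands level with compound 2 at the digits recorded, the two values lying within the scatter of each other.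

Compound 3 `O=C(O)CCCNC(=O)C1C(C(=O)O)[C@@H]2CC[C@H]1O2` differs from compound 1 by one change, (carboxy in place of hydrogen on a saturated chain carbon, three bonds along the chain from an amide-type nitrogen). Among the measured compounds shown here, no measured pair shows this change, so the step can only be guessed. With both measured compounds at the same weak level, the step is expected to be no change at the digits printed from compound 1 to compound 3 (within the scatter), that is, no change beyond the scatter. Compound 3 is therefore estimated to give 10000 nM in this assay, between 5000 nM and 20000 nM.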

Compound 3, concentration for 50% growth inhibition: 10000 nM
For compound 3 middle estimate and measured number coincide at the digits printed; the measured number falls inside the stated range.
By their numbers in this assay, from the lowest: compounds 1, 2 and 3 (each within the scatter of the next).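

In this assay, carboxy in place of hydrogen on a saturated chain carbon, three bonds along the chain from an amide-type nitrogen, gives no change at the digits printed from compound 1 to compound 3 (within the scatter). Among the compounds shown here, this is the first reading of any change at this position, and it shows that this read-out does not tell propyl from 3-carboxypropyl on the amide of the shared core, with compound 3 giving 10000 nM. One substitution at one chain carbon is all that this step covers, so it says nothing about other groups there.

From the compounds shown here alone, whether an amine at this chain carbon, or a longer chain ending in a carboxylic acid, would give a different value remains open. The data shown offer no measurement that bears on why the carboxy group leaves the value as it stands.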